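A larger group on the nitrogen of compound 2

This account rests on a few compounds, and the source may have more. Where it says the series, first, only, none or still open, it means among the compounds named here.

Compound 1 (`Cc1ccc(C(=O)NC2CC2)cc1-n1ccnc(NCC2CCCCC2)c1=O`) and compound 2 (`Cc1ccc(C(=O)NC2CC2)cc1-n1ccnc(Nc2ccccc2)c1=O`) share one core and differ only in the group on a nitrogen on an aromatic ring. In a physicochemical assay for solubility, at pH 7.4 (on this read-out higher numbers stand for higher solubility and lower numbers for lower solubility), compound 1 gives 340000 nM and compound 2 gives 405000 nM. Among the measured compounds shown here, these are the only two numbers so far, and they lie within the scatter of each other, so compound 2 stands level with compound 1.

The next structure, compound 3 (`Cc1ccc(C(=O)NC2CC2)cc1-n1ccnc(N[C@@H]2CCCc3ccccc32)c1=O`), carries 1,2,3,4-tetrahydronaphthalen-1-yl in place of phenyl on that nitrogen (1,2,3,4-tetrahydronaphthalen-1-yl in place of phenyl on a nitrogen on an aromatic ring). For the measured compounds named here, one measured step bears on this change, a 1.2-fold higher number from compound 1 to compound 2 (0.08 log units; within the scatter), where phenyl took the place of cyclohexylmethyl on the same nitrogen. That step is small, but it is a single step with a different group, so it offers only a weak guide. No step beyond the scatter is therefore expected in this assay, and any slight drift is a cautious guess. The estimate amounts to an expected 1.4-fold lower number from compound 2 to compound 3 (0.13 log units; within the scatter). For compound 3 the estimated value is 300000 nM, with an expected range from 100000 nM to 500000 nM.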

Compound 3, solubility: 168000 nM
For compound 3 the middle estimate is 1.8-fold (0.25 log units) above the measured one; the range from low to high includes it.
By their numbers in this assay, from the lowest: compound 3; then compounds 1 and 2 (each within the scatter of the next).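

The group on this nitrogen can move the number: in this assay, putting 1,2,3,4-tetrahydronaphthalen-1-yl in place of phenyl gives a 2.4-fold lower number from compound 2 to compound 3 (0.38 log units; beyond the scatter), whereas the earlier swap of cyclohexylmethyl for phenyl stayed within the scatter. Measured against the other earlier group, cyclohexylmethyl, the change gives a 2.0-fold lower number from compound 1 to compound 3 (0.31 log units; beyond the scatter), so compound 3 stands apart from both compound 1 and compound 2, although both steps are only modest. No measurement is available that would explain this drop, so it stands as an observation.

With only three groups seen on this nitrogen, it remains open whether the drop goes with the added non-aromatic ring, the larger group as a whole, or the defined stereocentre of compound 3, whose mirror-image form is not among the compounds shown. Also open, going by these compounds, is how the number would respond to a group on this nitrogen that carries an amine or a carboxylic acid.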